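The source may hold more compounds than are shown below. What is called first, only, known or untested is meant among the compounds shown, and "the series" means these compounds.

Measured so far in an assay on isolated protein for inhibition of lysine-specific demethylase 5C (Homo sapiens), read by AlphaScreen, with stated times of 15 min and 20 min; on this read-out higher numbers stand for weaker inhibition and lower numbers for stronger inhibition: compound 1, `Nc1nc(-c2cc(C(=O)O)ccn2)cs1`, gives 12 nM; compound 2, `NC(=O)c1ccnc(-c2csc(N)n2)c1`, gives 6800 nM; compound 3, `O=C(O)c1ccnc(-c2cscn2)c1`, gives 122 nM.

Compound 3 holds the second highest of the three numbers. Its nearest neighbour is compound 1, from which it is reached by a 10-fold higher number from compound 1 to compound 3 (1.01 log units; beyond the scatter). Compound 2 stands further away, with a markedly higher number than compound 3.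

Compound 4, `Cc1nc(-c2cc(C(=O)O)ccn2)cs1`, differs from compound 3 by methyl in place of hydrogen on an aromatic carbon. Among the compounds with values here, no measured step adds a methyl at this position. The step of a 10-fold higher number from compound 1 to compound 3 (1.01 log units; beyond the scatter) shows that this position matters, while a 570-fold higher number from compound 1 to compound 2 (2.75 log units; beyond the scatter) concerns the carboxylic acid and does not bear on it. A moderate step is therefore expected, estimated as a 1.5-fold lower number from compound 3 to compound 4 (0.18 log units; within the scatter). Compound 4 is expected at 80 nM, within 25 nM to 250 nM.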

Compound 4, half-maximal inhibitory concentration: 1700 nM
For compound 4 the middle estimate is 21-fold (1.33 log units) below the measured one; measured number outside the range, above it.
By their numbers in this assay, from the lowest: compound 1; then compound 3; then compound 4; then compound 2.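

On this aromatic carbon, a methyl group does not behave like a small neutral replacement for hydrogen: in this assay it weakens inhibition, with a 14-fold higher number from compound 3 to compound 4 (1.14 log units; beyond the scatter). Exchanging the amino group for methyl gives a 140-fold higher number from compound 1 to compound 4 (2.15 log units; beyond the scatter), so among these three compounds the order at this position runs from amino through hydrogen to methyl, and the earlier amino-to-hydrogen step alone did not reveal that a carbon substituent would fall below hydrogen. Nothing available explains why this position responds in this way. The compounds shown leave open how a methylamino group, a hydroxy group or a longer chain such as ethyl would fare on this carbon. They also leave open whether the same order would hold with the amide of compound 2 in place of the carboxylic acid.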